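A few compounds are considered here, and "the series" means these few. Any claim that something is new, unique, unknown or untested is made for them only; others in the source may bear on it.

The study covers three measured compounds and one that awaits measurement, all read in an ADME assay on HepG2 2.2.15 cells (Homo sapiens) for cytotoxicity; on this read-out lower numbers stand for higher toxicity in this test and higher numbers for lower toxicity in this test. Compound 1 `Cc1cc(C(C)C)ccc1OC(c1ccc(Cl)cc1)c1cnc(NC(=O)OC(C)(C)C)s1` gives a limit rather than a number, > 50000 nM. Compound 2 `O=C(Nc1ncc(C(Oc2ccc3cc(Br)ccc3c2)c2ccc(Cl)cc2)s1)c1cccs1` is reported in this assay as "not toxic" (no number reported), with no number attached. Compound 3 `O=C(Nc1ncc(C(OCc2ccc(F)cc2Br)c2ccccc2)s1)c1cccs1` is reported in this assay in the same way, as "not toxic" (no number reported). Compound 2 therefore stands without a single number of its own; of the other two values shown, one is a limit and one is an entry without a number, so no ordering among the three can be drawn from what is shown. The one fixed anchor is the limit of > 50000 nM in this assay, at which 1 of the 3 values shown sits.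

The compound to be measured is compound 4 `CCN(CC)C(=O)Nc1ncc(C(Oc2ccc3cc(Br)ccc3c2)c2ccc(Cl)cc2)s1`. It differs from compound 2 in one place: diethylamino in place of thiophen-2-yl on a carbonyl carbon. Among the measured compounds shown here, no step between measured compounds has been recorded, so there is no measured reference for a change of this kind. Given that compound 2 shows "not toxic" (no number reported) in this assay, and that no shown entry carries a single number, the expected step is none beyond the usual scatter, in neither direction. Compound 4 is estimated at 50000 nM in this assay, within a range from 20000 nM to 120000 nM, most likely reported again only as a limit.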

Compound 4, half-maximal cytotoxic concentration: "not toxic" (no number reported)
Compound 4 has no reported number here; the estimate stays without a comparison.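

Among the compounds shown here, compound 4, like compound 2, is reported in this assay as "not toxic" without a number, so no step between the two can be read. The compounds shown leave open whether exchanging thiophen-2-yl for diethylamino changes this read-out at all, and they offer only one anchor: the limit of > 50000 nM in this assay, at which 1 of the 4 values shown sits.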